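Chalcone series: cytotoxicity in Caco-2 cells, estimate for compound 4

The source may report more compounds than this note shows. Statements on the series, on what has been measured and on what is new or still open speak of the compounds shown alone.

Measured so far:
compound 1 `COc1cc(OC)c(C(=O)/C=C/c2ccc(Br)cc2)c(OC)c1` 6800 nM
compound 2 `COc1cccc(/C=C/C(=O)c2c(O)cc(OC)cc2OC)c1` 11200 nM
compound 3 `COc1cc(OC)c(C(=O)/C=C/c2ccc([N+](=O)[O-])cc2)c(OC)c1` 2600 nM

In a functional assay on Caco-2 cells (Homo sapiens) for cytotoxicity, with a stated time of 48 h (on this read-out higher numbers stand for weaker inhibition and lower numbers for stronger inhibition), compound 1 gives the second highest of the three numbers. Its nearest neighbour is compound 2, whose value lies within the scatter of that of compound 1, so no order between them is claimed. Compound 3 lies clearly lower: a 2.6-fold lower number from compound 1 to compound 3 (0.42 log units; beyond the scatter).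

Compound 4 `COc1cc(OC)c(C(=O)/C=C/c2ccccc2OC)c(OC)c1` differs from compound 1 by 2-methoxyphenyl in place of 4-bromophenyl on a double-bonded chain carbon bound to a double-bonded chain carbon. Going by the values given here, the only step that touches the same part of the molecule is the one from compound 1 to compound 3, and it concerns a nitro group, not a methoxy group, so it gives no direct guidance here. Compound 2, which carries a methoxy group on that ring, shows a value within the scatter of compound 1, but it also differs elsewhere. Among the compounds with values here, no measured step therefore predicts a shift beyond the scatter.

Compound 4 is expected to sit near compound 1, a 1.2-fold higher number from compound 1 to compound 4 (0.07 log units; within the scatter), with an estimated value of 8000 nM and a range from 3000 nM to 20000 nM.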

Compound 4, half-maximal inhibitory concentration: 4500 nM
Estimate against measurement, compound 4: 1.8-fold (0.25 log units) above; low and high end bracket the measured number.
By their numbers in this assay, from the lowest: compounds 3, 4, 1 and 2 (each within the scatter of the next, the first and the last beyond it).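

In this assay, 2-methoxyphenyl in place of 4-bromophenyl on a double-bonded chain carbon bound to a double-bonded chain carbon gives a 1.5-fold lower number from compound 1 to compound 4 (0.18 log units; within the scatter) and so no readable shift, which shows that this position accepts a methoxy-bearing ring as well as a bromo-bearing one. The exchange alters both the substituent and where it sits on the ring, so this single step cannot separate those two changes. No available evidence bears on this result. As far as these compounds go, whether an amine or a carboxylic acid on this ring would stay close to compound 1 remains open.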